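The source may report more compounds than this note shows. Statements on the series, on what has been measured and on what is new or still open speak of the compounds shown alone.

Measured compounds in an assay on HeLa cells for displacement of a labelled ligand from 5-hydroxytryptamine receptor 6 (Homo sapiens); a higher number here means a weaker inhibitor, a lower number a stronger inhibitor:
- compound 1, `O=S(=O)(c1ccccc1)c1cn(C2CCCNC2)c2ncccc12`, gives 4.9 nM
- compound 2, `O=S(=O)(c1cccc(Br)c1)c1cn(C2CCCNC2)c2ncccc12`, gives 3.8 nM
- compound 3, `O=S(=O)(c1ccccc1F)c1cn(C2CCCNC2)c2ncccc12`, gives 2 nM

Compound 3 shows the lowest number of the three. Its gap to compound 1 is the step of a 2.5-fold lower number from compound 1 to compound 3 (0.39 log units; beyond the scatter), which lies beyond the scatter, while its gap to compound 2, the step of a 1.9-fold lower number from compound 2 to compound 3 (0.28 log units; within the scatter), lies within it, so compound 3 and compound 2 cannot be told apart on these numbers.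

Compound 4, `O=S(=O)(C1=C(Cl)NC2SC=CN12)c1cn(C2CCCNC2)c2ncccc12`, is the unmeasured compound. It differs from compound 3 in this way: a group of 9 heavy atoms (5 carbon, 2 nitrogen, 1 sulfur, 1 chlorine; 2 five-membered non-aromatic rings with 2 hetero atoms each) in place of a group of 7 heavy atoms (6 carbon, 1 fluorine; one six-membered aromatic ring of carbon only), on a sulfonyl sulfur. The steps seen so far, a 1.3-fold lower number from compound 1 to compound 2 (0.11 log units; within the scatter) and a 2.5-fold lower number from compound 1 to compound 3 (0.39 log units; beyond the scatter), only swap one hydrogen on the phenyl ring for a halogen, and they moved the number little. None of them removes the phenyl ring itself, which is what happens here, so they bear on this change only loosely. With a whole new group on the sulfonyl sulfur, a larger shift than any seen so far is expected, and the direction is more likely towards a weaker binder, so the expected step is a 7.5-fold higher number from compound 3 to compound 4 (0.88 log units; beyond the scatter). For compound 4 the estimate in this assay is 15 nM, with a range from 3 nM to 80 nM.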

Compound 4, inhibition constant: 0.7 nM
Compound 4: the middle estimate sits 21-fold (1.33 log units) above what was measured; measured number below the stated range.
By their numbers in this assay, from the lowest: compound 4; then compounds 3, 2 and 1 (each within the scatter of the next, the first and the last beyond it).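

In this assay, among the compounds shown here, the earlier compounds showed only that a halogen on the phenyl ring moves the number a little, whereas replacing the 2-fluorophenyl itself gives a 2.9-fold lower number from compound 3 to compound 4 (0.46 log units; beyond the scatter) and so shows that a carbon-only aromatic ring is not required on this sulfonyl sulfur for a low number. Against the other two phenyl compounds the same new group gives a 5.4-fold lower number from compound 2 to compound 4 (0.73 log units; beyond the scatter) and a 7.0-fold lower number from compound 1 to compound 4 (0.85 log units; beyond the scatter) and all three steps lie beyond the scatter, which makes compound 4 the strongest binder of the four in this assay and shows that this position can still gain once the phenyl ring is gone. Nothing available here accounts for why this group with its two five-membered non-aromatic rings gives a lower number than the phenyl groups.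

From the compounds shown here alone, whether the chlorine of the new group matters stays open, as does whether a simpler group on the sulfonyl sulfur, such as a thiophene or a pyridine, would give a similar number. Going by these compounds, the shared core is the same in all four compounds, so what a methyl group on it would do alongside the new group also remains unknown.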